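Thiosemicarbazide series: amine swap on the thiocarbonyl carbon

A few compounds are considered here, and "the series" means these few. Any claim that something is new, unique, unknown or untested is made for them only; others in the source may bear on it.

Of the compounds shown here, three of the shared core have been read in a functional assay on A-375 cells (Homo sapiens) for cytotoxicity, read by MTT assay, with a stated time of 72 h, tested at 30 uM; on this read-out lower numbers stand for less inhibition of growth and higher numbers for more inhibition of growth at the one concentration tested. Compound 1 `Cc1cccc(/C(N)=N/NC(=S)N2CCSCC2)n1` gives 73.1% and stands lowest of the three numbers. Compound 2 `Cc1ccnc(/C(N)=N/NC(=S)N2CCN(c3ccccn3)CC2)c1` gives 79.4%, a value within the scatter of compound 1 and so not ordered against it. Compound 3 `N/C(=N\NC(=S)N1CCSCC1)c1ccccn1` gives 86%, the furthest from compound 1. Among the measured compounds shown here, the one single-point step among the measured compounds is a number 12.9 percentage points higher from compound 1 to compound 3 (beyond the scatter), a change on an aromatic carbon, not on the thiocarbonyl carbon.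

Compound 4 `Cc1cccc(/C(N)=N/NC(=S)N2CCCC2)n1` differs from compound 1 by pyrrolidin-1-yl in place of thiomorpholin-4-yl on a thiocarbonyl carbon. For the measured compounds named here, no measured pair differs only at this place: compound 2 carries another amine on the thiocarbonyl carbon but also differs on the aromatic ring, so its value says nothing separable about the amine swap. The step from compound 1 to compound 3 does not bear on this change either. With nothing to carry over, the expected step in this assay is a number 0.1 percentage points lower from compound 1 to compound 4 (within the scatter), none beyond the scatter. Compound 4 is therefore estimated at 73%, with a range from 55% to 88% that leaves room for movement in either direction.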

Compound 4, percent growth inhibition at one concentration: 60.8%
Beside the measured number, compound 4's estimate is 12.2 percentage points above it; measured number inside the range.
By their numbers in this assay, from the lowest: compound 4; then compounds 1, 2 and 3 (each within the scatter of the next, the first and the last beyond it).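

In this assay, among the compounds shown here, the amine on the thiocarbonyl carbon now proves to count on its own: with the rest of the core of compound 1 held fixed, pyrrolidin-1-yl in place of thiomorpholin-4-yl gives a number 12.3 percentage points lower from compound 1 to compound 4 (beyond the scatter), whereas the only earlier single-place step lay on an aromatic carbon. The swap alters several things at once, since a six-membered non-aromatic ring with 2 hetero atoms gives way to a five-membered one with 1 hetero atom and the ring sulfur goes, so this one pair cannot assign the step to ring size or to the loss of sulfur. Nothing at hand gives any measured account of why the number moves.

Piperidin-1-yl, which keeps the six-membered ring without the sulfur, and morpholin-4-yl, which puts oxygen in place of that sulfur, would be the groups to separate those two changes on the same core. As far as these compounds go, it also remains open whether pyrrolidin-1-yl gives a step of similar direction on the core of compound 3, which carries hydrogen in place of the methyl.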